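The source may report more compounds than this note shows. Statements on the series, on what has been measured and on what is new or still open speak of the compounds shown alone.

Compound 3 `CC(C)(C)c1ccc(C(=O)NCc2ccc(OCC(=O)O)cc2)cc1` gives the highest number of the three in an assay on HeLa cells with Bile acid receptor (Homo sapiens) as the target, read by a luciferase reporter, with a stated time of 24 h; a higher number here means that more compound is needed for the effect, a lower number that less compound is needed: compound 3 gives 730 nM, compound 1 `CC(C)(C)c1ccc(C(=O)NCc2ccc(OC(F)(F)F)cc2)cc1` gives 160 nM and compound 2 `CC(C)(C)c1ccc(C(=O)NCc2ccc(SC(F)(F)F)cc2)cc1` gives 0.4 nM. The two measured steps into compound 3 are a 4.6-fold higher number from compound 1 to compound 3 (0.66 log units; beyond the scatter) and a 1800-fold higher number from compound 2 to compound 3 (3.26 log units; beyond the scatter). Compound 4 `CC(C)(C)c1ccc(C(=O)NCc2ccc(CCC(=O)O)cc2)cc1` differs from compound 3 as follows: 2-carboxyethyl in place of carboxymethoxy on an aromatic carbon. Going by the values given here, no measured step exchanges one of these two acid-bearing chains for the other; the known steps all bear on fluorinated groups and do not reach this change. With nothing to lean on, no step beyond the scatter is expected in this assay, and the estimate for compound 4 is 700 nM, between 200 nM and 2500 nM, a step of a 1.0-fold lower number from compound 3 to compound 4 (0.02 log units; within the scatter).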

Compound 4, half-maximal effective concentration: 350 nM
For compound 4 the middle estimate is 2.0-fold (0.30 log units) above the measured one; low and high end bracket the measured number.
By their numbers in this assay, from the lowest: compound 2; then compound 1; then compound 4; then compound 3.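

At this position on the shared core, this assay separates the two acid-bearing chains: 2-carboxyethyl in place of carboxymethoxy gives a 2.1-fold lower number from compound 3 to compound 4 (0.32 log units; beyond the scatter), so the two are not interchangeable, although the step is modest. Compound 4 stays far from the (trifluoromethyl)sulfanyl group, with an 880-fold higher number from compound 2 to compound 4 (2.94 log units; beyond the scatter), and much nearer the trifluoromethoxy group, with a 2.2-fold higher number from compound 1 to compound 4 (0.34 log units; beyond the scatter). No measurement at hand accounts for these differences. Still open, from the compounds shown here alone, is how a longer chain ending in a carboxylic acid, or an amine at this position, would compare with 2-carboxyethyl.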